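The source may report more compounds than this note shows. Statements on the series, on what has been measured and on what is new or still open speak of the compounds shown alone.

Measured compounds:
compound 1, `Oc1cc(I)ccc1CNc1ccc(C2CCCCC2)cc1`, "not active" (no number reported) in a functional assay on Jurkat cells (Homo sapiens) for activation, with a stated time of 24 h; on this read-out lower numbers stand for an effect already at smaller amounts and higher numbers for an effect only at larger amounts of compound
compound 2, `Oc1ccccc1CNc1ccc(C2CCCCC2)cc1`, 8800 nM in this assay

Compound 2 holds the only number shown in this assay, where it gives 8800 nM. Going by the values given here, compound 1 carries an iodine on its phenol ring and is reported in this assay as "not active" (no number reported), with no number attached, so no step between the two can be sized.

Compound 3, `CC(Nc1ccc(C2CCCCC2)cc1)c1ccccc1O`, has not yet been measured in this assay. It differs from compound 2 by methyl in place of hydrogen on a saturated chain carbon bound to an aromatic carbon and a nitrogen on an aromatic ring. Among the compounds with values here, no step between measured compounds is available to guide the expectation for this change. Within the data shown here, a small step is expected for a 1.5-fold lower number from compound 2 to compound 3 (0.17 log units; within the scatter), in either direction, or none beyond the usual scatter, because the only anchor is compound 2 with 8800 nM.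

Compound 3 is therefore estimated to give 6000 nM in this assay, with a range from 1500 nM to 25000 nM.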

Compound 3, half-maximal effective concentration: "not active" (no number reported)
Compound 3 has no reported number here; no gap can be computed for the estimate.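

In this assay, going by these compounds alone, compound 1 is likewise reported without a number, and compound 3 is reported as "not active" (no number reported), so no step from compound 2 to either compound can be read. The compounds shown leave open how large any change with methyl in place of hydrogen is. No evidence bears on this result.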